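The source may report more compounds than this note shows. Statements on the series, on what has been measured and on what is new or still open speak of the compounds shown alone.

Of the compounds shown here, two sharing one core have been measured in an assay on CHO cells for binding affinity to Melanocortin receptor 4 (Homo sapiens); on this read-out higher numbers stand for weaker inhibition and lower numbers for stronger inhibition. Compound 1 `COc1ccc(-n2nc(Sc3ccc(Cl)cc3)cc(CC[C@@H](C)NC(=O)[C@H]3CNCC[C@@H]3c3ccc(Cl)cc3Cl)c2=O)cc1` gives 3.2 nM. Within the data shown here, compound 2 `COc1ccc(-n2nc(Sc3ccc(Cl)cc3)cc(CC[C@@H](C)NC(=O)[C@H]3CNCC[C@@H]3c3cccc(C(F)(F)F)c3)c2=O)cc1` gives 100 nM, the higher of the two numbers measured so far; the only measured step, a 31-fold higher number from compound 1 to compound 2 (1.49 log units; beyond the scatter), shows that exchanging the aryl group on the saturated ring carbon can shift the read-out a great deal. Compound 3 `COc1ccc(-n2nc(Sc3ccc(Cl)cc3)cc(CC[C@@H](C)NC(=O)[C@H]3CNCC[C@@H]3c3ccc(C)cc3)c2=O)cc1` is not yet measured. It differs from compound 2 in one place: 4-methylphenyl in place of 3-(trifluoromethyl)phenyl on a saturated ring carbon. Among the measured compounds shown here, no measured step involves a 4-methylphenyl group at this position, so the direction of the change cannot be read from the data directly; the one step that bears on it, a 31-fold higher number from compound 1 to compound 2 (1.49 log units; beyond the scatter), only marks how much this position can matter, and shows that the 2,4-dichlorophenyl group of compound 1 gave the lower number. A moderate move toward lower numbers is therefore expected, with wide uncertainty, and the estimated step is a 3.3-fold lower number from compound 2 to compound 3 (0.52 log units; beyond the scatter). Compound 3 is estimated at 30 nM, with a range from 6 nM to 150 nM.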

Compound 3, half-maximal inhibitory concentration: 4.7 nM
Beside the measured number, compound 3's estimate is 6.4-fold (0.81 log units) above it; measured number outside the range, below it.
By their numbers in this assay, from the lowest: compounds 1 and 3 (each within the scatter of the next); then compound 2.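

Replacing 3-(trifluoromethyl)phenyl with 4-methylphenyl gives a 21-fold lower number from compound 2 to compound 3 (1.33 log units; beyond the scatter) in this assay, so a large swing at this saturated ring carbon can be reversed by a group that contains no halogen at all. The comparison with the 2,4-dichlorophenyl group gives a 1.5-fold higher number from compound 1 to compound 3 (0.17 log units; within the scatter) and lies within the scatter, so these two quite different aryl groups cannot be told apart here, and the chlorine atoms of compound 1 are not required for a low number. Nothing available explains why 3-(trifluoromethyl)phenyl stands apart from the other two groups. The compounds shown leave open whether the trifluoromethyl group itself or its place on the aryl ring sets the higher number, a question that 4-(trifluoromethyl)phenyl and 3-methylphenyl groups would address. They also leave open how an unsubstituted phenyl group would compare.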